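From Compound 2 to Compound 3: An Aryl Exchange

A few compounds are considered here, and "the series" means these few. Any claim that something is new, unique, unknown or untested is made for them only; others in the source may bear on it.

Measured in a physicochemical assay for solubility, read by spectrophotometry; a lower number here means a less soluble compound, a higher number a more soluble compound:
- Compound 1 `O=C(Nc1ccc(Cl)c(Cl)c1)c1cc(Br)ccc1O`: < 100000 nM
- Compound 2 `O=C(Oc1ccc(Br)cc1C(=O)Nc1ccc(C(F)(F)F)cc1)c1cnc(Cl)cn1`: < 100000 nM

The record so far is the limit of < 100000 nM in this assay, at which 2 of the 2 values shown sit. Compound 2 therefore stands only at a limit of the assay, < 100000 nM, and not at a number. Compound 3 `O=C(Oc1ccc(Br)cc1C(=O)Nc1ccc(Cl)c(Cl)c1)c1cnc(Cl)cn1` carries 3,4-dichlorophenyl in place of 4-(trifluoromethyl)phenyl on an amide-type nitrogen. Among the measured compounds shown here, no measured step bears directly on this change. Compound 1, which also carries 3,4-dichlorophenyl, gives < 100000 nM, again a limit and not a number. With that reading for compound 1, no shift beyond the scatter is expected in this assay, and compound 3 may well report a limit too. The estimated step, a step that the limit leaves unreadable from compound 2 to compound 3, is expected to stay within the scatter. Compound 3 is expected to read 60000 nM, with an estimated range of 15000 nM to 100000 nM.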

Compound 3, solubility: < 100000 nM
Compound 3: no number, only a limit; the forecaster's own chance of this, stated with the estimate: 85%; the middle value is on the limit's open side.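

Compound 3 gives only a limit in this assay, as do compound 1 and compound 2, so neither step to compound 3 can be read: the limit of < 100000 nM in this assay, at which 3 of the 3 values shown sit.

The compounds shown leave open where any of the three actually stands, and whether exchanging 4-(trifluoromethyl)phenyl for 3,4-dichlorophenyl shifts the read-out at all.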